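This account rests on a few compounds, and the source may have more. Where it says the series, first, only, none or still open, it means among the compounds named here.

Compounds measured in a functional assay on RXF 393 cells (Homo sapiens) for cytotoxicity, read by sulforhodamine B assay, with a stated time of 48 h, tested at 0.01 uM; on this read-out higher numbers stand for a weaker effect at the one concentration tested and lower numbers for a stronger effect:
compound 1 `COc1cc(-c2cc(/C=C/C(=O)c3ccc(N)cc3)[nH]n2)cc(OC)c1OC` gives 91%;
compound 2 `COc1ccc(-c2cc(/C=C/C(=O)c3ccc(OC)c(OC)c3)[nH]n2)cc1` gives 82%.

Compound 1 has the highest of the two numbers; compound 2 stands within the usual scatter of it, so the two values show no real difference. Compound 3 `COc1cc(-c2cc(/C=C/C(=O)c3ccc(Cl)c(Cl)c3)[nH]n2)cc(OC)c1OC` differs from compound 1 at one place: 3,4-dichlorophenyl in place of 4-aminophenyl on a carbonyl carbon. For the measured compounds named here, no pair of measured compounds shows this change, so the size of the step has no precedent here. Compound 3 is expected to give 88%, between 70% and 100%. The step of a number 3 percentage points lower from compound 1 to compound 3 (within the scatter) is thus estimated to stay within the scatter, with no direction established.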

Compound 3, a percentage reported as activity, at one concentration (the size of the read-out at that concentration, not a potency): 96%
Compound 3: middle estimate off by 8 percentage points, on the low side; measured number inside the range.
By their numbers in this assay, from the lowest: compounds 2, 1 and 3 (each within the scatter of the next, the first and the last beyond it).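

In this assay, 3,4-dichlorophenyl in place of 4-aminophenyl on a carbonyl carbon gives a number 5 percentage points higher from compound 1 to compound 3 (within the scatter). This first single-place comparison shows that, at the one concentration tested, the exchange leaves no real difference, even though the two groups differ in their hydrogen-bond donors and acceptors. No measured property bears on this result.

On these data alone, whether any group at this place could bring the number down beyond the scatter remains open, for instance a 4-hydroxyphenyl or a 4-carboxyphenyl. As far as these compounds go, whether the two compounds would also match at other concentrations remains open too.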